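The compounds below may be only part of what the source reports. "The series", "measured", "known", "first", "only" and "open" are said of these compounds alone.

Of the compounds shown here, three that share one core have been measured in a functional assay on NCI-H322 cells (Homo sapiens) for cytotoxicity, read by MTT assay, with a stated time of 24 h; on this read-out higher numbers stand for weaker inhibition and lower numbers for stronger inhibition. Compound 1 `COc1ccc(/C=C\C(=O)O)c(OCc2cn(-c3ccc(NC(=O)c4ccccc4)cc3)nn2)c1CC=C(C)C` gives 17200 nM. Compound 2 `COc1cccc(-n2cc(COc3c(/C=C\C(=O)O)ccc(OC)c3CC=C(C)C)nn2)c1` gives 25200 nM, and compound 3 `COc1ccc(/C=C\C(=O)O)c(OCc2cn(-c3cccc(C#N)c3)nn2)c1CC=C(C)C` gives 26500 nM. The number for compound 3 is the highest of the three, yet its distance to compound 2 and its distance to compound 1 each lie within the usual scatter, so these three numbers cannot be told apart with confidence. For the measured compounds named here, the one step among them that changes a single place, a 1.1-fold higher number from compound 2 to compound 3 (0.02 log units; within the scatter), is the exchange of methoxy for cyano on an aromatic carbon, and it falls within the scatter.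

Compound 4 `COc1ccc(/C=C\C(=O)O)c(OCc2cn(-c3ccccc3)nn2)c1CC=C(C)C` has not yet been measured. It differs from compound 3 by hydrogen in place of cyano on an aromatic carbon; cut one bond further out, this reads as 3-cyanophenyl to phenyl. Going by the values given here, the only measured step that bears on it is a 1.1-fold higher number from compound 2 to compound 3 (0.02 log units; within the scatter), which shows that swapping one group for another on this ring left this assay essentially unmoved. Taking the cyano away altogether is expected to behave alike, giving a step of a 1.1-fold lower number from compound 3 to compound 4 (0.03 log units; within the scatter) with no direction beyond the scatter. Compound 4 is therefore estimated at 25000 nM, within a range from 10000 nM to 60000 nM.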

Compound 4, half-maximal inhibitory concentration: 29200 nM
Compound 4: middle estimate off by 1.2-fold (0.07 log units), on the low side, and the stated range covers the measured number.
By their numbers in this assay, from the lowest: compounds 1, 2, 3 and 4 (each within the scatter of the next).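

For the compounds shown here, compound 4 supplies the plain phenyl reference that the earlier compounds lacked, so each group on this ring can now be set against hydrogen rather than only against another group. In this assay, going by these compounds alone, taking away the cyano (a 1.1-fold higher number from compound 3 to compound 4 (0.04 log units; within the scatter)), the methoxy (a 1.2-fold higher number from compound 2 to compound 4 (0.06 log units; within the scatter)) or the benzamido, which brings a second aromatic ring and an amide (a 1.7-fold higher number from compound 1 to compound 4 (0.23 log units; within the scatter)), each gives a step within the scatter, so none of these three groups can be told apart from plain hydrogen, and no compound among the four goes against this. Nothing available explains why these exchanges leave the number within the scatter.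

The compounds shown leave open whether an amine, a hydroxyl group or a chlorine atom on this ring, or two groups on it at once, would give a step beyond the scatter. They also leave open how far the number depends on the shared core, which stays the same in all four compounds, and whether a change there would matter more than any change on the outer ring.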